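Replacing acetyl with 2-(ethoxycarbonyl)ethyl on the shared core

The source may hold more compounds than are shown below. What is called first, only, known or untested is meant among the compounds shown, and "the series" means these compounds.

For the measured compounds named here, in a functional assay (trachea) with Cavia porcellus as the target (on this read-out higher numbers stand for weaker inhibition and lower numbers for stronger inhibition), compound 3 `CC(=O)Cn1nc(-c2cccnc2)c2ccccc2c1=O` gives 40700 nM, the highest number of the three measured so far. Compound 1 `CC(C)=CCn1nc(-c2cccnc2)c2ccccc2c1=O` gives 1380 nM, and compound 2 `O=c1c2ccccc2c(-c2cccnc2)nn1CC1CCCCC1` gives 209 nM. Compound 4 `CCOC(=O)CCCn1nc(-c2cccnc2)c2ccccc2c1=O` carries 2-(ethoxycarbonyl)ethyl in place of acetyl on a saturated chain carbon bound to an aromatic nitrogen. Two large measured steps introduce acetyl at that place: a 29-fold higher number from compound 1 to compound 3 (1.47 log units; beyond the scatter) and a 190-fold higher number from compound 2 to compound 3 (2.29 log units; beyond the scatter). The step of a 6.6-fold lower number from compound 1 to compound 2 (0.82 log units; beyond the scatter) is modest. Going by the values given here, no measured compound carries ethoxycarbonyl, so the evidence is indirect. A sizeable step toward a lower number is therefore expected in this assay. The expected change is a 14-fold lower number from compound 3 to compound 4 (1.13 log units; beyond the scatter). For compound 4 the estimated value is 3000 nM, within an expected range of 500 nM to 18000 nM.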

Compound 4, half-maximal inhibitory concentration: 10000 nM
For compound 4 the middle estimate is 3.3-fold (0.52 log units) below the measured one; the range from low to high includes it.
By their numbers in this assay, from the lowest: compound 2; then compound 1; then compound 4; then compound 3.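

In this assay, 2-(ethoxycarbonyl)ethyl recovers only part of what acetyl gives up: a 4.1-fold lower number from compound 3 to compound 4 (0.61 log units; beyond the scatter) is modest, against a 48-fold higher number from compound 2 to compound 4 (1.68 log units; beyond the scatter) and a 7.2-fold higher number from compound 1 to compound 4 (0.86 log units; beyond the scatter). Across the four compounds, the two groups holding a carbonyl give higher numbers than cyclohexyl and 2-methylprop-1-en-1-yl, with none going against this. Nothing available explains this order. As far as these compounds go, whether the added chain length or the ethoxycarbonyl drives the step from acetyl stays open, and so does how a carboxylic acid or an amine at the end of that chain would read.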